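The source may report more compounds than this note shows. Statements on the series, on what has been measured and on what is new or still open speak of the compounds shown alone.

In a functional assay on MCF7 cells (Homo sapiens) for inhibition, read by trypan blue exclusion, with a stated time of 3 days (a higher number here means a weaker inhibitor, a lower number a stronger inhibitor), compound 2 (`COc1cc(C(=O)c2cn(-c3cccc(F)c3)cc2-c2ccccc2)cc(OC)c1OC`) gives 350 nM as the higher of two numbers, while compound 1 (`COc1cc(C(=O)c2cn(-c3ccccc3F)cc2-c2ccccc2)cc(OC)c1OC`) gives 85 nM in the same read-out. Compound 3 (`COc1cc(C(=O)c2cn(-c3cccc(N)c3)cc2-c2ccccc2)cc(OC)c1OC`) differs from compound 2 by amino in place of fluoro on an aromatic carbon with the rest unchanged. Among the measured compounds shown here, the only measured step (a 4.1-fold higher number from compound 1 to compound 2 (0.61 log units; beyond the scatter)) swaps 2-fluorophenyl for 3-fluorophenyl and shows nothing directly about amino, so it sets only a modest scale. A modest step to a lower number is expected in this assay although the direction remains uncertain. The expected step is a 2.3-fold lower number from compound 2 to compound 3 (0.37 log units; beyond the scatter) on this reasoning. In this assay compound 3 is estimated at 150 nM with an expected range of 30 nM to 700 nM as the working figure.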

Compound 3, half-maximal inhibitory concentration: 74 nM
The estimate for compound 3 lay 2.0-fold (0.31 log units) above the measured number; measured number inside the range.
By their numbers in this assay, from the lowest: compounds 3 and 1 (each within the scatter of the next); then compound 2.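

Moving from 3-fluorophenyl to 3-aminophenyl in this assay gives a 4.7-fold lower number from compound 2 to compound 3 (0.67 log units; beyond the scatter), so the higher number of compound 2 does not hold for every group on this aromatic carbon. The step of a 1.1-fold lower number from compound 1 to compound 3 (0.06 log units; within the scatter) leaves 3-aminophenyl and 2-fluorophenyl indistinguishable in this read-out. No measurement available accounts for the amino change. Going by these compounds, what a hydroxyl, methoxy or acetamido group does on the same aromatic carbon remains open. Also open, on these data alone, is whether amino on other carbons of this ring matches compound 3.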